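This account rests on a few compounds, and the source may have more. Where it says the series, first, only, none or still open, it means among the compounds named here.

Measured compounds:
Compound 1, `Nc1ncnc2c1c(-c1cnc3[nH]ccc3c1)nn2CCCCCCC(=O)NO`: 19800 nM
Compound 2, `Nc1nc2cc(-c3nn(CCCCCCC(=O)NO)c4ncnc(N)c34)ccc2o1`: 11900 nM

Going by the values given here, compound 1 gives the highest of the two numbers so far in a functional assay on MCF7 cells (Homo sapiens) for inhibition, read by MTT assay, with a stated time of 72 h (on this read-out lower numbers stand for stronger inhibition and higher numbers for weaker inhibition), and its nearest neighbour is compound 2, which differs by a 1.7-fold lower number from compound 1 to compound 2 (0.22 log units; within the scatter), so the two compounds cannot be told apart on these data. That single step concerns the aromatic group attached to the shared core, not the end of the chain.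

Compound 3, `CNC(=O)CCCCCCCn1nc(-c2cnc3[nH]ccc3c2)c2c(N)ncnc21`, is not yet measured. It differs from compound 1 by (methylcarbamoyl)methyl in place of hydroxycarbamoyl on a saturated chain carbon, six bonds along the chain from an aromatic nitrogen. Among the compounds with values here, no measured step touches this position: the one step known, from compound 1 to compound 2, leaves the chain end untouched and therefore says nothing about the present change. The expectation for compound 3 thus rests on the value of compound 1 alone, and it is held loosely. Compound 3 is estimated at 40000 nM, with a range from 12000 nM to 150000 nM, which would mean an expected step of a 2.0-fold higher number from compound 1 to compound 3 (0.31 log units; beyond the scatter), with a real chance that this assay reports only a limit.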

Compound 3, half-maximal inhibitory concentration: 7570 nM
The estimate for compound 3 lay 5.3-fold (0.72 log units) above the measured number; the measured number lies below the stated range.
By their numbers in this assay, from the lowest: compounds 3, 2 and 1 (each within the scatter of the next, the first and the last beyond it).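

In this assay, the saturated chain carbon six bonds along the chain from an aromatic nitrogen proves to be a place where the group can be changed with a readable effect: (methylcarbamoyl)methyl in place of hydroxycarbamoyl gives a 2.6-fold lower number from compound 1 to compound 3 (0.42 log units; beyond the scatter). The hydroxycarbamoyl group is therefore not needed for a number of this size on this read-out, and its removal moves the number down rather than up, although the step is modest and rests on a single pair of compounds. No measured information bears on why the number moves in this direction, and the cell read-out by itself does not say what lies behind the change.

The compounds shown leave open whether the same change would give a similar step on the aromatic group of compound 2, as the (methylcarbamoyl)methyl end appears here only with the aromatic group of compound 1. They also leave open how a carboxylic acid, an amine or a longer chain at this place would compare with compound 3.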